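Trifluoromethyl on the Phenyl Ring and Vero Cell Tolerance

The source may report more compounds than this note shows. Statements on the series, on what has been measured and on what is new or still open speak of the compounds shown alone.

Measured compounds:
compound 1, `C[C@]1(CN2CCc3nc(-c4ccccc4)ccc3C2)Cn2cc([N+](=O)[O-])nc2O1`: > 32 ug/mL
compound 2, `C[C@]1(CN2CCn3cc(-c4ccc(F)cc4)nc3C2)Cn2cc([N+](=O)[O-])nc2O1`: "not determined" (no result reported)
compound 3, `C[C@]1(CN2CCn3nc(-c4ccc(F)c(F)c4)nc3C2)Cn2cc([N+](=O)[O-])nc2O1`: "not determined" (no result reported)

In an ADME assay on Vero cells (Chlorocebus sabaeus) for cytotoxicity, read by MTT assay, with a stated time of 72 h (a lower number here means that less compound is tolerated, a higher number that more compound is tolerated), compound 1 gives > 32 ug/mL, which is a limit of the assay and not a single number. Compound 1 therefore stands at the limit of > 32 ug/mL in this assay, at which 1 of the 3 values shown sits, and no finer value is known for it. For compound 2 this assay reports "not determined" (no result reported). For compound 3 this assay likewise reports "not determined" (no result reported). Within the data shown here, no step between two measured compounds can be read from these three entries.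

Compound 4, `C[C@]1(CN2CCc3nc(-c4ccc(C(F)(F)F)cc4)ccc3C2)Cn2cc([N+](=O)[O-])nc2O1`, differs from compound 1 in one place: trifluoromethyl in place of hydrogen on an aromatic carbon. Among the measured compounds shown here, since compound 1 itself sits only at a limit in this assay, there is no measured step on which a direction for compound 4 could be grounded. The expected step from compound 1 to compound 4 in this assay is an at least 1.0-fold lower number from compound 1 to compound 4 (0.02 log units; that floor lies within the scatter), which is taken to lie within the scatter. Compound 4 is thus estimated to give 30 ug/mL in this assay, with a range from 12 ug/mL to 64 ug/mL, and a fair chance that again only a limit is reported.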

Compound 4, half-maximal cytotoxic concentration: > 32 ug/mL
Compound 4 gave a limit, no number (the forecaster's own chance of this, stated with the estimate: 60%); at least 1.0-fold (0.02 log units) between middle value and limit.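

In this assay compound 1 and compound 4 both stand at a limit and not at a number, so the step between them cannot be read: the limit of > 32 ug/mL in this assay, at which 2 of the 4 values shown sit. The compounds shown leave open how far either is tolerated past that limit, and whether trifluoromethyl in place of hydrogen changes tolerance at all.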